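Notes on the isoxazole series: compound 3 to compound 4

The source may report more compounds than this note shows. Statements on the series, on what has been measured and on what is new or still open speak of the compounds shown alone.

Measured compounds:
Compound 1, `CCNC(=O)c1noc(-c2cc(C(C)C)c(O)cc2O)c1-c1cc(CNC(=O)CC)no1`, 78 nM in a functional assay on HCT-116 cells (Homo sapiens) for inhibition; a higher number here means a weaker inhibitor, a lower number a stronger inhibitor.
Compound 2, `CCNC(=O)c1noc(-c2cc(C(C)C)c(O)cc2O)c1-c1cc(CN2CCCC2)no1`, 51 nM.
Compound 3, `CCNC(=O)c1noc(-c2cc(C(C)C)c(O)cc2O)c1-c1cc(C(=O)OCC)no1`, "not determined" (no result reported) in this assay.

Compound 3 has no number in this assay, so it cannot be placed against compound 1 or compound 2; the only anchors for the shared core are those two values, which lie close together.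

Compound 4 is `CCNC(=O)c1noc(-c2cc(C(C)C)c(O)cc2O)c1-c1cnn(C)c1`. The change from compound 3 to compound 4 is 1-methyl-1H-pyrazol-4-yl in place of 3-(ethoxycarbonyl)-1,2-oxazol-5-yl on an aromatic carbon.

Among the compounds with values here, the one measured step, a 1.5-fold lower number from compound 1 to compound 2 (0.18 log units; within the scatter), alters a substituent on the same five-membered ring that is exchanged here, and it stayed within the scatter. That step does not touch the ring itself, so it bears on this change only loosely: it shows that the core tolerates variation at that position, but nothing more. Within the data shown here, no measured step covers exchange of the whole ring, and no direction can be read from the data.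

Compound 4 is therefore expected to land near the two measured values, with wide uncertainty: estimated 150 nM, in the range 30 nM to 800 nM.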

Compound 4, half-maximal inhibitory concentration: 41 nM
Compound 4: middle estimate off by 3.7-fold (0.56 log units), on the high side; low and high end bracket the measured number.
By their numbers in this assay, from the lowest: compounds 4, 2 and 1 (each within the scatter of the next).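

The change from compound 3 to compound 4 cannot be read as a step: compound 3 has no single number in this assay, while compound 4 gives 41 nM. The compounds shown leave open what exchanging 3-(ethoxycarbonyl)-1,2-oxazol-5-yl for 1-methyl-1H-pyrazol-4-yl does to the number on the shared core. No supporting evidence bears on this result.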